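A few compounds are considered here, and "the series" means these few. Any claim that something is new, unique, unknown or untested is made for them only; others in the source may bear on it.

Of the compounds shown here, two have been measured so far. Compound 1 `CNC(=O)N1CCCc2ccc(NC(=O)c3cccc(-c4ccn(S(C)(=O)=O)n4)c3)cc21` gives 37% in a functional assay on MV4-11 cells (Homo sapiens) for antiproliferative activity, with a stated time of 6 days, tested at 6.25 uM; on this read-out lower numbers stand for a weaker effect and higher numbers for a stronger effect at the one concentration tested. Going by the values given here, compound 2 `CNC(=O)N1CCCc2ccc(NC(=O)c3ccc(-c4ccn(C(C)=O)n4)cc3)cc21` gives 91.4% in this assay, the higher of the two numbers, and compound 1, its only neighbour, sits a long way below it, well beyond the usual scatter. The next compound, compound 3 `CNC(=O)N1CCCc2ccc(NC(=O)c3ccc(-c4cccnc4)cc3)cc21`, differs from compound 2 in a single place: pyridin-3-yl in place of 1-acetyl-1H-pyrazol-3-yl on an aromatic carbon. Among the compounds with values here, no measured pair isolates this change, so the expectation rests on the structure alone; a moderate decrease is expected, a number 31.4 percentage points lower from compound 2 to compound 3 (beyond the scatter). Compound 3 is accordingly estimated at 60%, with a likely range from 25% to 90%.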

Compound 3, a percentage reported as inhibition, at one concentration (the size of the read-out at that concentration, not a potency): 92.1%
The estimate for compound 3 lay 32.1 percentage points below the measured number; the whole stated range lies below it.
By their numbers in this assay, from the lowest: compound 1; then compounds 2 and 3 (each within the scatter of the next).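

In this assay, putting pyridin-3-yl in place of 1-acetyl-1H-pyrazol-3-yl on this aromatic carbon gives a number 0.7 percentage points higher from compound 2 to compound 3 (within the scatter). At this position, then, neither the five-membered ring nor its acetyl group is required for a high number, since a six-membered aromatic ring with fewer heavy atoms serves as well. Nothing available explains why the two groups read alike.

Still open, from the compounds shown here alone, is whether a plain phenyl ring or a carboxylic acid on this carbon would hold the number. A single tested concentration also cannot show whether the two compounds differ in potency.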